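Working notes: replacing the 4-methoxybenzyl group of compound 2

The source may report more compounds than this note shows. Statements on the series, on what has been measured and on what is new or still open speak of the compounds shown alone.

Measured in a functional assay, read by spectrophotometry, with a stated time of 30 min (on this read-out higher numbers stand for weaker inhibition and lower numbers for stronger inhibition), so far
- compound 1 `CC(C)(C)c1cc(CCC(=O)NCCC2CCN(Cc3ccccc3)CC2)cc(C(C)(C)C)c1O` gives 54500 nM 
- compound 2 `COc1ccc(CN2CCC(CCNC(=O)/C=C/c3cc(C(C)(C)C)c(O)c(C(C)(C)C)c3)CC2)cc1` gives 61200 nM 

Compound 2 at 61200 nM stands level with compound 1 at 54500 nM and the two values lie within the scatter of each other. Compound 3 `CC(C)(C)c1cc(/C=C/C(=O)NCCC2CCN(Cc3ccc(F)c(F)c3)CC2)cc(C(C)(C)C)c1O` differs from compound 2 by 3,4-difluorophenyl in place of 4-methoxyphenyl on a saturated chain carbon bound to an amine nitrogen in a ring and this reads as 4-methoxybenzyl to 3,4-difluorobenzyl. For the measured compounds named here, no measured step covers this exchange, so nothing beyond the scatter is expected in this assay and no direction is favoured. The expected 1.2-fold lower number from compound 2 to compound 3 (0.09 log units; within the scatter) stays within that scatter. In this assay compound 3 is expected at 50000 nM with a range from 15000 nM to 120000 nM as estimated.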

Compound 3, half-maximal inhibitory concentration: 65700 nM
For compound 3 the middle estimate is 1.3-fold (0.12 log units) below the measured one; low and high end bracket the measured number.
By their numbers in this assay, from the lowest: compounds 1, 2 and 3 (each within the scatter of the next).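

In this assay, 3,4-difluorophenyl in place of 4-methoxyphenyl on a saturated chain carbon bound to an amine nitrogen in a ring gives a 1.1-fold higher number from compound 2 to compound 3 (0.03 log units; within the scatter). For the compounds shown here, this is the first one-place step read at this position, and it shows that the exchange, which removes the one hydrogen-bond acceptor counted on the group, leaves the number within the scatter. No supporting measurement bears on this result.

On these data alone, whether a pyridine ring or a phenyl group carrying a carboxylic acid at this place would move the number beyond the scatter remains open.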